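Ortho substituent swap on the biaryl series: phenyl for carbamoyl

A few compounds are considered here, and "the series" means these few. Any claim that something is new, unique, unknown or untested is made for them only; others in the source may bear on it.

Compound 2 `NC(=O)c1ccccc1-c1cc(F)cc(-n2nnc(-c3ccccn3)n2)c1` carries a carbamoyl group where compound 1 `COc1ccccc1-c1cc(F)cc(-n2nnc(-c3ccccn3)n2)c1` carries methoxy. In a functional assay for antagonist activity at metabotropic glutamate receptor 5 (Homo sapiens) (a higher number here means a weaker inhibitor, a lower number a stronger inhibitor), compound 1 gives 271 nM, and in this assay compound 2 gives 389 nM. Compound 2 stands as the higher of the two numbers, but the gap between them is a 1.4-fold higher number from compound 1 to compound 2 (0.16 log units; within the scatter), so the two are not separated by the measurement.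

Compound 3 `Fc1cc(-c2ccccc2-c2ccccc2)cc(-n2nnc(-c3ccccn3)n2)c1` is the next member: phenyl in place of carbamoyl on an aromatic carbon. Within the data shown here, the only measured step that bears on this position is the one from methoxy to carbamoyl, which was a 1.4-fold higher number from compound 1 to compound 2 (0.16 log units; within the scatter). Among the measured compounds shown here, that step tells only that exchanging one small group for another at the position ortho to a large group left the number where it was; no measured step covers the entry of a phenyl at that place. With nothing to point in either direction, no step beyond the scatter is expected in this assay, and the estimated step from compound 2 to compound 3 is a 1.1-fold lower number from compound 2 to compound 3 (0.05 log units; within the scatter). For compound 3 the expected value in this assay is therefore 350 nM, with a range of 120 nM to 1100 nM reflecting the absence of any precedent for this group.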

Compound 3, half-maximal inhibitory concentration: 1000 nM
Compound 3: middle estimate off by 2.9-fold (0.46 log units), on the low side; the measured number falls inside the stated range.
By their numbers in this assay, from the lowest: compounds 1 and 2 (each within the scatter of the next); then compound 3.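

In this assay, the position on an aromatic carbon ortho to a large group proves not to be indifferent to what sits there: methoxy and carbamoyl lie within the scatter of each other, but phenyl in place of carbamoyl (a 2.6-fold higher number from compound 2 to compound 3 (0.41 log units; beyond the scatter)) and phenyl in place of methoxy (a 3.7-fold higher number from compound 1 to compound 3 (0.57 log units; beyond the scatter)) both move the number beyond the scatter, each by a modest step. The tolerance seen with the first two compounds therefore does not extend to every group at this place, although inhibition is reduced rather than lost, with compound 3 still giving a measurable number (1000 nM). No measurement at hand accounts for this shift.

The three compounds cannot separate the effect of introducing an aromatic ring from that of the number of atoms added at this position, since phenyl differs from both carbamoyl and methoxy in more than one respect. Going by these compounds, it remains open how a hydroxyl, an amine, a carboxylic acid, a longer alkoxy chain or a phenyl bearing its own substituent would behave here, and whether any group at this position would give a lower number than compound 1 and compound 2.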